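Phenoxy to Chloro: an Expected Step Toward Weaker Inhibition

A few compounds are considered here, and "the series" means these few. Any claim that something is new, unique, unknown or untested is made for them only; others in the source may bear on it.

Measured in an assay on isolated protein for inhibition of matrix metalloproteinase-9 (Homo sapiens); on this read-out higher numbers stand for weaker inhibition and lower numbers for stronger inhibition:
compound 1 `C=C[C@@H]1OC(c2ccc(Br)cc2)=N[C@H]1SC(C)=O`, 88000 nM
compound 2 `C=C[C@@H]1OC(c2ccc(-c3ccccc3)cc2)=N[C@H]1Sc1ccccc1`, > 100000 nM, which is a limit of the assay and not a number
compound 3 `C=C[C@@H]1OC(c2ccc(Oc3ccccc3)cc2)=N[C@H]1CO`, 32000 nM

Among the numbers shown, compound 3 holds the lowest one, and compound 1 stands a good way higher, beyond the usual scatter. Compound 2 reaches only (the limit of > 100000 nM in this assay, at which 1 of the 3 values shown sits). Compound 4 `C=C[C@@H]1OC(c2ccc(Cl)cc2)=N[C@H]1CO` differs from compound 3 by chloro in place of phenoxy on an aromatic carbon. For the measured compounds named here, no step between two measured compounds isolates this change, so its size in this assay is unknown; a shift toward weaker inhibition, modest but possibly beyond the scatter, is expected. Compound 4 is therefore estimated at 65000 nM, with a range from 20000 nM to 200000 nM. That estimate amounts to an expected step of a 2.0-fold higher number from compound 3 to compound 4 (0.31 log units; beyond the scatter).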

Compound 4, inhibition constant: 33000 nM
The estimate for compound 4 lay 2.0-fold (0.29 log units) above the measured number, and the stated range covers the measured number.
By their numbers in this assay, from the lowest: compounds 3 and 4 (each within the scatter of the next); then compound 1. At a limit, above all of these: compound 2.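

In this assay chloro in place of phenoxy on this aromatic carbon gives a 1.0-fold higher number from compound 3 to compound 4 (0.01 log units; within the scatter) and leaves the two compounds indistinguishable. For the compounds shown here, at this position, the phenoxy group and its aromatic ring can therefore be exchanged for a single chlorine atom without a change beyond the scatter, which the earlier compounds, differing in more than one place, could not show. Nothing measured here bears on why the two groups match. Still open, on these data alone, is how an amine, a carboxylic acid or a longer chain would read at this aromatic carbon.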